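Trifluoromethyl for nitro on a triazolothiadiazine series

The source may hold more compounds than are shown below. What is called first, only, known or untested is meant among the compounds shown, and "the series" means these compounds.

Of the compounds shown here, three sharing one core have been measured in a functional assay on HCT-116 cells (Homo sapiens) for inhibition, read by sulforhodamine B assay, with a stated time of 72 h; a lower number here means a stronger inhibitor, a higher number a weaker inhibitor. Compound 1 `COc1ccc2cc(C(C)c3nnc4n3N=C(c3ccc([N+](=O)[O-])cc3)CS4)ccc2c1` gives 15100 nM in this assay, the highest number of the three. For the measured compounds named here, compound 2 `CC(c1ccc(-c2ccccc2)c(F)c1)c1nnc2n1N=C(c1ccc(OC(F)(F)F)cc1)CS2` gives 5400 nM, and compound 3 `CC(C)Cc1ccc(C(C)c2nnc3n2N=C(c2ccc(Cl)cc2)CS3)cc1` gives 6700 nM; the gaps from compound 1 to each of these lie beyond the usual scatter, so compound 1 is the weakest inhibitor among the three measured so far. As compounds 2 and 3 differ from compound 1 in more than one place, no single structural step can be read from their numbers.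

The next compound keeps everything of compound 1 except one substituent. Compound 4 `COc1ccc2cc(C(C)c3nnc4n3N=C(c3ccc(C(F)(F)F)cc3)CS4)ccc2c1` carries a trifluoromethyl in place of nitro on an aromatic carbon. Going by the values given here, no measured pair in this set isolates such a change, so there is no direct precedent for its size or direction. The step of a 1.5-fold lower number from compound 1 to compound 4 (0.18 log units; within the scatter) is therefore expected to be modest, not far beyond the scatter, and if anything toward a lower number. Compound 4 is estimated to give 10000 nM in this assay, with a plausible range from 4000 nM to 28000 nM.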

Compound 4, half-maximal inhibitory concentration: 10800 nM
Compound 4: the middle estimate sits 1.1-fold (0.03 log units) below what was measured; the measured number falls inside the stated range.
By their numbers in this assay, from the lowest: compounds 2, 3, 4 and 1 (each within the scatter of the next, the first and the last beyond it).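

In this assay, for the compounds shown here, trifluoromethyl in place of nitro on an aromatic carbon para to a large group gives a 1.4-fold lower number from compound 1 to compound 4 (0.15 log units; within the scatter), the first step in this set that can be read at a single place. Nitro carries 2 hydrogen-bond acceptors and trifluoromethyl 0, so in this one pair, the 4-nitrophenyl to 4-(trifluoromethyl)phenyl exchange removes those acceptors with no difference beyond the scatter. Nothing at hand explains why the two groups read alike.

The compounds shown leave open whether a group of another kind on this same aromatic carbon, such as an amine, a carboxylic acid or a longer alkyl chain, would move the number beyond the scatter. They also leave open whether trifluoromethyl in place of nitro would give a similar step if the rest of the molecule differed from compound 1, as this single pair speaks only for that one background.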